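Moving a methoxy group around the piperidine ring

A few compounds are considered here, and "the series" means these few. Any claim that something is new, unique, unknown or untested is made for them only; others in the source may bear on it.

Measured compounds:
compound 1, `O=C(N1CCC(F)CC1)N1CC(c2nc(-c3cccc(Cl)c3)no2)C1`, 990 nM
compound 2, `O=C(C1CCC(F)(F)CC1)N1CC(c2nc(-c3cccc(Cl)c3)no2)C1`, 180 nM
compound 3, `COC1CCN(C(=O)N2CC(c3nc(-c4cccc(Cl)c4)no3)C2)CC1`, > 10000 nM

All three share a core and differ only in the group on the carbonyl carbon. In an assay on HEK293 cells for positive allosteric modulation of metabotropic glutamate receptor 5 (Homo sapiens), read by FLIPR (on this read-out lower numbers stand for an effect already at smaller amounts and higher numbers for an effect only at larger amounts of compound), compound 2 gives the lowest number of the set, and the change from compound 1 to compound 2 is a 5.5-fold lower number from compound 1 to compound 2 (0.74 log units; beyond the scatter). Compound 3 sits at a limit of the assay, (the limit of > 10000 nM in this assay, at which 1 of the 3 values shown sits), so no exact number is known for it. The change from compound 1 to compound 3 is an at least 10-fold higher number from compound 1 to compound 3 (1.00 log units; beyond the scatter), and that from compound 2 to compound 3 is an at least 55-fold higher number from compound 2 to compound 3 (1.74 log units; beyond the scatter).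

Compound 4, `COC1CCCN(C(=O)N2CC(c3nc(-c4cccc(Cl)c4)no3)C2)C1`, has not been measured. It differs from compound 3 as follows: 3-methoxypiperidin-1-yl in place of 4-methoxypiperidin-1-yl on a carbonyl carbon. Going by the values given here, no measured step shifts a methoxy group from one ring carbon to another, so the only guidance is that compound 3 already lies at the limit and that both steps leading to it are beyond the scatter. Compound 4 is therefore expected to stay in the same weak region, with the step of a number no higher from compound 3 to compound 4 (the limit leaves the size open) estimated at around none beyond the scatter. Compound 4 is estimated at 10000 nM, in a range from 3000 nM to 30000 nM, with a real chance that only a limit is reported.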

Compound 4, half-maximal effective concentration: > 10000 nM
Compound 4 ended at the assay's limit (the forecaster's own chance of this, stated with the estimate: 60%); the middle value lies on the limit itself.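

In this assay compound 4 sits at a limit and gives no exact number, just as compound 3 does, so moving the methoxy group from 4-methoxypiperidin-1-yl to 3-methoxypiperidin-1-yl does not bring back a readable value: the limit of > 10000 nM in this assay, at which 2 of the 4 values shown sit. The step between these two compounds cannot be read, so neither placement of the methoxy group can be ranked above the other. What the result adds is that the poor showing of compound 3 is not confined to one ring carbon, since the second placement also falls far short of the two compounds with fluorine, with an at least 55-fold higher number from compound 2 to compound 4 (1.74 log units; beyond the scatter) and an at least 10-fold higher number from compound 1 to compound 4 (1.00 log units; beyond the scatter).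

The compounds shown leave open whether a hydroxyl or an ethoxy group on the piperidine ring would return a readable value, or whether any oxygen-bearing group at these ring carbons stays at the limit. They also do not tell whether 3-fluoropiperidin-1-yl would keep a measurable effect like that of compound 1, which gives 990 nM, and so whether placement on the ring matters at all when the methoxy group is absent.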